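A larger group replaces pyridin-4-yl in compound 3

This account rests on a few compounds, and the source may have more. Where it says the series, first, only, none or still open, it means among the compounds named here.

Compound 1 `CCC(Oc1c(N)ncc2c(-c3cnn(C4CCNCC4)c3)coc12)c1c(Cl)ccc(F)c1Cl` gives 3600 nM
Compound 2 `C#CCC(Oc1c(N)ncc2c(-c3cnn(C4CCNCC4)c3)coc12)c1c(Cl)ccc(F)c1Cl` gives 360 nM
Compound 3 `C[C@@H](Oc1c(N)ncc2c(-c3ccncc3)coc12)c1c(Cl)ccc(F)c1Cl` gives 900 nM

In a functional assay on MKN-45 cells (Homo sapiens) for antiproliferative activity, read by CellTiter-Glo, with a stated time of 3 days (on this read-out lower numbers stand for stronger inhibition and higher numbers for weaker inhibition), compound 3 gives 900 nM and so holds the middle place of the three, with compound 1 higher and compound 2 lower. Compound 4 `C[C@@H](Oc1c(N)ncc2c(C3=CCN(C(=O)N(C)C)CC3)coc12)c1c(Cl)ccc(F)c1Cl` differs from compound 3 by one change, a group of 11 heavy atoms (8 carbon, 2 nitrogen, 1 oxygen; one six-membered non-aromatic ring with 1 hetero atom) in place of a group of 6 heavy atoms (5 carbon, 1 nitrogen; one six-membered aromatic ring with 1 hetero atom), on an aromatic carbon and pyridin-4-yl is the group that leaves. Among the compounds with values here, the only measured step is a 10-fold lower number from compound 1 to compound 2 (1.00 log units; beyond the scatter) and it concerns ethynyl in place of methyl on a saturated chain carbon, not this group. Within the data shown here, no measured step therefore bears on this swap, so no step beyond the scatter is expected in this assay and the range stays wide. The expected change is a 1.1-fold lower number from compound 3 to compound 4 (0.05 log units; within the scatter) as a rough estimate. For compound 4 the estimated value is 800 nM with an expected range from 200 nM to 3500 nM as the likely span.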

Compound 4, half-maximal inhibitory concentration: 510 nM
The estimate for compound 4 lay 1.6-fold (0.20 log units) above the measured number, and the stated range covers the measured number.
By their numbers in this assay, from the lowest: compounds 2, 4 and 3 (each within the scatter of the next, the first and the last beyond it); then compound 1.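

In this assay, the swap at this aromatic carbon, two ring bonds from the ring oxygen, gives a 1.8-fold lower number from compound 3 to compound 4 (0.25 log units; within the scatter). So a much larger group with a non-aromatic six-membered ring can stand here in place of pyridin-4-yl without a change beyond the scatter, and an aromatic ring at this place is not needed to keep the number in this range. No supporting measurement is available to explain this result.

Going by these compounds, it remains open which part of the entering group counts, the ring double bond or the dimethylamino carbonyl on the ring nitrogen. On these data alone, how a carboxylic acid or a morpholine ring would read at this place also remains open.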